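Swapping Tert-Butyl for Neopentyl: What Happens to Clearance?

A few compounds are considered here, and "the series" means these few. Any claim that something is new, unique, unknown or untested is made for them only; others in the source may bear on it.

Measured in an ADME assay on liver for metabolic stability, with Liver microsome (Homo sapiens) as the target, read by LC-MS, using microsomes; on this read-out lower numbers stand for slow clearance and higher numbers for fast clearance:
- compound 1 `O=C(NCc1cc(Cl)ccc1-n1cnnn1)[C@@H]1C[C@@H]2C[C@@H]2N1C(=O)[C@H](O)CC1CC1`: < 12 mL.min-1.g-1, a limit of the assay
- compound 2 `CC(C)(C)[C@@H](O)C(=O)N1[C@H](C(=O)NCc2cc(Cl)ccc2-n2cnnn2)C[C@@H]2C[C@@H]21`: 75 mL.min-1.g-1

Among the compounds with values here, compound 2, at 75 mL.min-1.g-1, holds the only exact number so far. Compound 3 `CC(C)(C)C[C@@H](O)C(=O)N1[C@H](C(=O)NCc2cc(Cl)ccc2-n2cnnn2)C[C@@H]2C[C@@H]21` differs from it by neopentyl in place of tert-butyl on a saturated chain carbon bound to a carbonyl carbon and an oxygen on a saturated carbon, with neopentyl in place of tert-butyl. Within the data shown here, only one measured step bears on this place, an at least 6.2-fold higher number from compound 1 to compound 2 (0.79 log units; beyond the scatter), and it lies beyond the scatter. That step involves a different swap, so its size does not carry over, and only a small fall is expected. The estimated change is a 1.7-fold lower number from compound 2 to compound 3 (0.22 log units; within the scatter), probably within the scatter. For compound 3 the expected value is 45 mL.min-1.g-1, with an estimated range of 15 mL.min-1.g-1 to 130 mL.min-1.g-1.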

Compound 3, intrinsic clearance in microsomes: 40 mL.min-1.g-1
Compound 3: the middle estimate sits 1.1-fold (0.05 log units) above what was measured; the range from low to high includes it.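

In this assay, neopentyl in place of tert-butyl gives a 1.9-fold lower number from compound 2 to compound 3 (0.27 log units; within the scatter), so the two groups cannot be told apart at this position. Tert-butyl in place of cyclopropyl gives an at least 3.3-fold higher number from compound 1 to compound 3 (0.52 log units; beyond the scatter), so compound 3 stays clearly separated from compound 1, just as compound 2 does. Compound 1 stands at a limit of the assay: the limit of < 12 mL.min-1.g-1 in this assay, at which 1 of the 3 values shown sits.

Still open, going by these compounds, is what a cyclohexyl group or an amine on this chain would do to the number. The compounds shown also leave open whether a longer chain would stay close to compound 3.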